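Sirtuin-6 Inhibition: Dodecyl in Place of Phenyl

The source may hold more compounds than are shown below. What is called first, only, known or untested is meant among the compounds shown, and "the series" means these compounds.

Measured compounds:
compound 1 `O=C(CCCSC[C@H](NC(=O)OCc1ccccc1)C(=O)Nc1ccccc1)NCc1ccccc1` — 30%
compound 2 `CCCCNC(=O)CCCSC[C@H](NC(=O)OCc1ccccc1)C(=O)Nc1ccccc1` — 26%

In an assay for inhibition of NAD-dependent protein deacylase sirtuin-6 (Homo sapiens), read by HPLC, with stated times of 15 min and 1 h, tested at 333 uM (on this read-out lower numbers stand for less inhibition and higher numbers for more inhibition at the one concentration tested (going by the name of the read-out)), compound 1 gives 30%, the higher of the two numbers measured, while compound 2 gives 26%. Among the compounds with values here, the single measured step, a number 4 percentage points lower from compound 1 to compound 2 (within the scatter), lies within the scatter, so the two compounds cannot be ordered on these data. Compound 3 `CCCCCCCCCCCCCNC(=O)CCCSC[C@H](NC(=O)OCc1ccccc1)C(=O)Nc1ccccc1` has not yet been measured in this assay. It differs from compound 1 by dodecyl in place of phenyl on a saturated chain carbon bound to an amide-type nitrogen. Within the data shown here, the only step that bears on this change is the one from compound 1 to compound 2, where the phenyl also gave way to a saturated chain, and that step, a number 4 percentage points lower from compound 1 to compound 2 (within the scatter), was within the scatter. Among the measured compounds shown here, the chain entering in compound 3 is longer than the one in compound 2, but no measured pair shows what a longer chain does here. On this basis the step of a number 3 percentage points lower from compound 1 to compound 3 (within the scatter) is expected to stay within the scatter. Compound 3 is therefore estimated to give 27% in this assay, with a range from 10% to 45%.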

Compound 3, a percentage reported as inhibition, at one concentration (the size of the read-out at that concentration, not a potency): 31%
Compound 3: middle estimate off by 4 percentage points, on the low side; measured number inside the range.
By their numbers in this assay, from the lowest: compounds 2, 1 and 3 (each within the scatter of the next).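

In this assay, dodecyl in place of phenyl on a saturated chain carbon bound to an amide-type nitrogen gives a number 1 percentage points higher from compound 1 to compound 3 (within the scatter), so this place now carries a chain of 12 heavy atoms without the number leaving the scatter of the compound with the aromatic ring. Nonyl in place of hydrogen on a saturated chain carbon, four bonds along the chain from an amide-type nitrogen, gives a number 5 percentage points higher from compound 2 to compound 3 (within the scatter), which means that the two saturated chains, like the phenyl, cannot be ordered and that no dependence on chain length can be read from these three compounds. No measured evidence accounts for this result.

Because each number comes from a single concentration, the compounds shown leave open whether they would differ in potency if full concentration series were compared. They also leave open whether a carboxylic acid or an amine on the end of the chain, or a chain longer than dodecyl, would move the number beyond the scatter in this assay.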